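Pyrazole Attachment Point Shift in a P2X7 Antagonist Series

The source may hold more compounds than are shown below. What is called first, only, known or untested is meant among the compounds shown, and "the series" means these compounds.

Measured compounds:
compound 1, `COc1ccc(-c2ccc(Cl)c(C(=O)NCC3(O)CCCCCC3)c2)nn1`, 280 nM
compound 2, `Cn1ccc(-c2ccc(Cl)c(C(=O)NCC3(O)CCCCCC3)c2)n1`, 238 nM

Of the compounds shown here, two have been measured in a functional assay on cells for antagonist activity at P2X purinoceptor 7 (Homo sapiens), in the presence of a further agent that is not named here; on this read-out lower numbers stand for stronger inhibition and higher numbers for weaker inhibition. Compound 1 gives 280 nM and compound 2 gives 238 nM. Compound 2 carries the lower of the two numbers, but the step of a 1.2-fold lower number from compound 1 to compound 2 (0.07 log units; within the scatter) falls within the scatter, so the two compounds cannot be ordered against each other on this evidence.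

Compound 3, `Cn1nccc1-c1ccc(Cl)c(C(=O)NCC2(O)CCCCCC2)c1`, has not been measured. It differs from compound 2 only in how the same atoms are joined: 1-methyl-1H-pyrazol-5-yl in place of 1-methyl-1H-pyrazol-3-yl on an aromatic carbon. For the measured compounds named here, the only measured step, from compound 1 to compound 2, exchanged one heteroaryl ring for another of different ring size and gave no movement beyond the scatter in this assay. Going by the values given here, no measured pair addresses a change in the attachment point of the pyrazole itself, so there is no direct precedent. Given the quiet response of this assay to the one heteroaryl exchange seen, compound 3 is expected to land close to compound 2, with a step of a 1.3-fold higher number from compound 2 to compound 3 (0.10 log units; within the scatter) and no direction beyond the scatter. The estimate for compound 3 in this assay is 300 nM, within a range from 100 nM to 900 nM.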

Compound 3, half-maximal inhibitory concentration: > 1000 nM
Compound 3 was reported as a limit (the forecaster's own chance of this, stated with the estimate: 5%); at least 3.3-fold (0.52 log units) between middle value and limit.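

In this assay, this position on the six-membered aromatic ring of carbon only, para to the chloro group, proves sensitive to how the pyrazole is joined: with the same atoms in both compounds, moving from 1-methyl-1H-pyrazol-3-yl to 1-methyl-1H-pyrazol-5-yl gives an at least 4.2-fold higher number from compound 2 to compound 3 (0.62 log units; beyond the scatter). The earlier exchange of 6-methoxypyridazin-3-yl for 1-methyl-1H-pyrazol-3-yl had stayed within the scatter, whereas putting 1-methyl-1H-pyrazol-5-yl in place of the same 6-methoxypyridazin-3-yl gives an at least 3.5-fold higher number from compound 1 to compound 3 (0.55 log units; beyond the scatter), so the quiet response seen earlier does not extend to every heteroaryl group at this position. The value of compound 3 is a limit of the assay and not a number: the limit of > 1000 nM in this assay, at which 1 of the 3 values shown sits.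

Going by these compounds, it remains open how 1-methyl-1H-pyrazol-4-yl would stand at this position in this assay, and whether 1-ethyl-1H-pyrazol-5-yl or the unsubstituted 1H-pyrazol-5-yl would follow compound 3 or compound 2. The compounds shown also offer no read-out other than this one, so they give no account of why the two methylpyrazole attachments part.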